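Fluoro in Place of Methyl: Expected Cytotoxicity of Compound 4

A few compounds are considered here, and "the series" means these few. Any claim that something is new, unique, unknown or untested is made for them only; others in the source may bear on it.

Measured compounds:
compound 1, `Cc1cccc(C[C@H]2C(=O)OC[C@@H]2Cc2ccccc2)c1`: 53000 nM
compound 2, `O=C1OC[C@H](Cc2ccccc2)[C@H]1Cc1cccc(F)c1`: 75000 nM
compound 3, `Cc1cccc(C[C@H]2COC(=O)[C@@H]2Cc2ccc(Cl)c(Cl)c2)c1`: 22000 nM

Three compounds were measured in a functional assay on HL-60 cells (Homo sapiens) for cytotoxicity, read by WST assay, with a stated time of 48 h; on this read-out higher numbers stand for an effect only at larger amounts of compound and lower numbers for an effect already at smaller amounts. In this assay compound 1 gives 53000 nM, and compound 2 gives 75000 nM. Compound 2 differs from compound 1 by fluoro in place of methyl on an aromatic carbon, and this change made a step of a 1.4-fold higher number from compound 1 to compound 2 (0.15 log units; within the scatter), so the two numbers are not told apart by the measurement. Compound 3 gives 22000 nM in this assay, the lowest of the three numbers, and its gap to compound 1 as well as to compound 2 lies beyond the scatter. The difference between the core of compound 3 and the core of compound 1 is not broken down here.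

Compound 4, `O=C1OC[C@H](Cc2cccc(F)c2)[C@H]1Cc1ccc(Cl)c(Cl)c1`, has not yet been measured. It differs from compound 3 by fluoro in place of methyl on an aromatic carbon, the same change as from compound 1 to compound 2, at the same place. Because the earlier step was a 1.4-fold higher number from compound 1 to compound 2 (0.15 log units; within the scatter), the step from compound 3 to compound 4 is expected to be similar, namely a 1.4-fold higher number from compound 3 to compound 4 (0.13 log units; within the scatter). Compound 4 is therefore estimated to give 30000 nM in this assay, with a plausible range from 14000 nM to 65000 nM. This expectation rests on a single earlier pair only, and whether the change carries over to the core of compound 3 is not known.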

Compound 4, half-maximal effective concentration: 14000 nM
Compound 4: the middle estimate sits 2.1-fold (0.33 log units) above what was measured; the range from low to high includes it.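

In this assay, the same exchange on the second core gave a 1.6-fold lower number from compound 3 to compound 4 (0.20 log units; within the scatter), and set beside the earlier step it reads: the same change on two cores in this assay, a 1.4-fold higher number (0.15 log units; within the scatter) from compound 1 to compound 2 and a 1.6-fold lower number (0.20 log units; within the scatter) from compound 3 to compound 4, 2.2-fold (0.35 log units) apart, within the scatter of two such steps

This shows that, for these two pairs, going from 3-methylphenyl to 3-fluorophenyl left the number within the scatter on both the core of compound 1 and the core of compound 3, and that the two steps cannot be told apart from each other. It does not show that the change has no effect at all, nor that it would behave the same way on any further core, since the comparison rests on two pairs in a single cell assay with numbers this large.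

The compounds shown carry only methyl or fluoro at this place, and they leave open what a chloro, a methoxy, a nitrile or an amine there would give. They also leave open whether the two steps would still match on a core bearing a carboxylic acid or a longer chain.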